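Swapping pyridin-4-yl for phenyl on the shared core

The source may hold more compounds than are shown below. What is called first, only, known or untested is meant among the compounds shown, and "the series" means these compounds.

Of the compounds shown here, three with a common core have been tested in an assay on isolated protein for inhibition of DNA topoisomerase 1 (Homo sapiens), with a stated time of 30 min, tested at 100 uM; on this read-out higher numbers stand for a stronger effect at the one concentration tested and lower numbers for a weaker effect. Compound 3 `Oc1ccc(-c2cc(-c3ccncc3)nc(-c3cccc(Cl)c3)c2)cc1` gives 29.2% and has the highest number of the three. Compound 1 `Oc1ccc(-c2cc(-c3ccsc3)nc(-c3cccc(Cl)c3)c2)cc1` gives 26%, and compound 2 `Oc1cccc(-c2cc(-c3ccccc3)nc(-c3cccc(Cl)c3)c2)c1` gives 11.5%, which places compound 2 well below compound 3 while compound 1 and compound 3 lie within the usual scatter of one another.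

Compound 4 `Oc1ccc(-c2cc(-c3ccccc3)nc(-c3cccc(Cl)c3)c2)cc1` has not yet been measured. It differs from compound 3 in one place: phenyl in place of pyridin-4-yl on an aromatic carbon. Going by the values given here, the only measured step that bears on this position is the exchange of ring at the same aromatic carbon, a number 3.2 percentage points higher from compound 1 to compound 3 (within the scatter), which stayed within the scatter. Compound 2 also carries phenyl there but with the hydroxy group elsewhere, so its lower value cannot be tied to the phenyl alone. A change of a number 4.2 percentage points lower from compound 3 to compound 4 (within the scatter) is therefore expected, that is, nothing beyond the scatter. For compound 4 the estimate in this assay is 25%, with a range from 10% to 38%.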

Compound 4, a percentage reported as inhibition, at one concentration (the size of the read-out at that concentration, not a potency): 0%
Estimate against measurement, compound 4: 25 percentage points above; measured number outside the range, below it.
By their numbers in this assay, from the lowest: compound 4; then compound 2; then compounds 1 and 3 (each within the scatter of the next).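

Going by these compounds alone, the ring at this position matters more than the earlier compounds suggested in this assay: with phenyl in place of pyridin-4-yl, there is a number 29.2 percentage points lower from compound 3 to compound 4 (beyond the scatter), although the change is only a ring nitrogen replaced by carbon. The exchange with thiophen-3-yl gives a similar picture, with a number 26 percentage points lower from compound 1 to compound 4 (beyond the scatter), so both rings carrying a hetero atom stand apart from phenyl, even though they lie within the scatter of each other. With phenyl held fixed, the place of the hydroxy group also counts, since 4-hydroxyphenyl in place of 3-hydroxyphenyl gives a number 11.5 percentage points lower from compound 2 to compound 4 (beyond the scatter).

No measurement at hand explains why phenyl behaves so differently from the other two rings. As far as these compounds go, it also remains open whether a pyridin-3-yl ring or an open-chain amine at this position would give a read-out like that of compound 3.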